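This account rests on a few compounds, and the source may have more. Where it says the series, first, only, none or still open, it means among the compounds named here.

Compound 1 `Cc1c(Nc2nc(N)c3c(C#N)c(N4CCC[C@H]4C)n(C)c3n2)cnn1C` is the starting point of this small set; in an assay on isolated protein for inhibition of Leucine-rich repeat serine/threonine-protein kinase 2 variant G2019S (Homo sapiens), read by TR-FRET and LanthaScreen, with stated times of 50 min and 30 min, in the presence of a further agent that is not named here (a lower number here means a stronger inhibitor, a higher number a weaker inhibitor), compound 1 gives 43 nM. Compound 2 `Cc1c(Nc2nc(N)c3c(C#N)c(N4CCC[C@H]4C)n(C)c3n2)cnn1CC1(O)COC1` differs from it in one place, (3-hydroxyoxetan-3-yl in place of hydrogen on a saturated chain carbon bound to an aromatic nitrogen), and in this assay compound 2 gives 10 nM, so that a 4.3-fold lower number from compound 1 to compound 2 (0.63 log units; beyond the scatter). Compound 3 `Cc1nn(C)cc1Nc1nc(N)c2c(C#N)c(N3CCC[C@H]3C)n(C)c2n1` has the same atoms as compound 1 joined differently; in this assay compound 3 gives 30 nM, and a 1.4-fold lower number from compound 1 to compound 3 (0.16 log units; within the scatter), a gap that is within the scatter, so no order between compound 1 and compound 3 can be read.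

Compound 4 `Cc1nn(CC2(O)COC2)cc1Nc1nc(N)c2c(C#N)c(N3CCC[C@H]3C)n(C)c2n1` has not yet been measured. It stands to compound 3 as compound 2 stands to compound 1: 3-hydroxyoxetan-3-yl in place of hydrogen on a saturated chain carbon bound to an aromatic nitrogen, a change seen twice among these compounds, made at the same place each time. The two cores on which it is made differ by 1,3-dimethyl-1H-pyrazol-4-yl in place of 1,5-dimethyl-1H-pyrazol-4-yl on a nitrogen on an aromatic ring. Because a 4.3-fold lower number from compound 1 to compound 2 (0.63 log units; beyond the scatter), the same change on the core of compound 3 is expected to give a step of about a 3.8-fold lower number from compound 3 to compound 4 (0.57 log units; beyond the scatter), resting on that single earlier pair. Compound 4 is therefore estimated at 8 nM, with a likely range from 3 nM to 20 nM.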

Compound 4, half-maximal inhibitory concentration: 51 nM
The estimate for compound 4 lay 6.4-fold (0.80 log units) below the measured number, outside the stated range (above it).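

In this assay, the step on the second core reads a 1.7-fold higher number from compound 3 to compound 4 (0.23 log units; within the scatter), so no order between these two compounds can be read. Carrying 3-hydroxyoxetan-3-yl in place of hydrogen from one core to the other therefore did not reproduce the earlier step, and in this series the effect of this change depends on the core that carries it: the same change on two cores in this assay, a 4.3-fold lower number (0.63 log units; beyond the scatter) from compound 1 to compound 2 and a 1.7-fold higher number (0.23 log units; within the scatter) from compound 3 to compound 4, 7.3-fold (0.86 log units) apart, beyond the scatter of two such steps This does not show what produces the difference, and it rests on a single pair on each core, so it gives no general rule for other cores.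

The compounds shown leave open whether a smaller group at the same place, such as a 2-hydroxyethyl chain, would also give steps that differ between the 1,5-dimethyl-1H-pyrazol-4-yl and 1,3-dimethyl-1H-pyrazol-4-yl cores. They also leave open how an amine or a carboxylic acid on that saturated chain carbon would behave on these two cores.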